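A few compounds are considered here, and "the series" means these few. Any claim that something is new, unique, unknown or untested is made for them only; others in the source may bear on it.

Three compounds have been measured in a functional assay on MCF7 cells (Homo sapiens) for cytotoxicity, read by MTT assay, with a stated time of 72 h, tested at 100 uM; on this read-out higher numbers stand for more inhibition of growth at the one concentration tested and lower numbers for less inhibition of growth:

Compound 1 `N/C(=N\NC(=S)N1CCOCC1)c1ccccn1`: 81.6%
Compound 2 `Cc1ccnc(/C(N)=N/NC(=S)N2CCSCC2)c1`: 76.8%
Compound 3 `N/C(=N\NC(=S)N1CCSCC1)c1ccccn1`: 72.4%

Compound 3 gives the lowest of the three numbers, yet both gaps to it are within the scatter, so the three compounds cannot be told apart on these values. Compound 4 `N/C(=N\NC(=S)N1CCCCC1)c1ccccn1` differs from compound 3 by piperidin-1-yl in place of thiomorpholin-4-yl on a thiocarbonyl carbon. The step that bears most directly on this change is a number 9.2 percentage points lower from compound 1 to compound 3 (within the scatter), also a swap of one ring at the same thiocarbonyl carbon; the other step, a number 4.4 percentage points lower from compound 2 to compound 3 (within the scatter), lies elsewhere. Both were within the scatter, so no step beyond the scatter is expected in this assay. For compound 4 the estimate is 74%, within 58% to 88%, meaning an expected step of a number 1.6 percentage points higher from compound 3 to compound 4 (within the scatter).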

Compound 4, percent growth inhibition at one concentration: 77.7%
Beside the measured number, compound 4's estimate is 3.7 percentage points below it; the measured number falls inside the stated range.
By their numbers in this assay, from the lowest: compounds 3, 2, 4 and 1 (each within the scatter of the next).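

In this assay, the thiocarbonyl carbon now also carries a ring with a single hetero atom, and this change gives a number 5.3 percentage points higher from compound 3 to compound 4 (within the scatter) and a number 3.9 percentage points lower from compound 1 to compound 4 (within the scatter). At this position, piperidin-1-yl therefore cannot be told apart from thiomorpholin-4-yl or morpholin-4-yl, so the second ring hetero atom shows no clear effect at the one concentration tested. No supporting measurement offers an explanation for this result. On these data alone, it remains open whether an open-chain dimethylamino group or a ring carrying a carboxylic acid at this carbon would give a similar number.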